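Shortening the Ring in an Inactive Short-Chain Compound

The source may hold more compounds than are shown below. What is called first, only, known or untested is meant among the compounds shown, and "the series" means these compounds.

Measured in a functional assay on DU-145 cells (Homo sapiens) for inhibition, read by MTT assay, with stated times of 18 h and 4 h; a lower number here means a stronger inhibitor, a higher number a weaker inhibitor:
compound 1 `CCCOP(=O)(O)OCCSC(=S)N1CCCCC1`: > 100000 nM (a limit)
compound 2 `CCCCCCCCOP(=O)(O)OCCSC(=S)N1CCCCC1`: > 100000 nM (a limit)
compound 3 `CCCCCCCCCCOP(=O)(O)OCCSC(=S)N1CCCCC1`: 29300 nM

Compound 1 has no exact number, only the limit > 100000 nM, and it shares that limit with one other compound: the limit of > 100000 nM in this assay, at which 2 of the 3 values shown sit.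

Compound 4 `CCCOP(=O)(O)OCCSC(=S)N1CCCC1` makes one change to compound 1: pyrrolidin-1-yl in place of piperidin-1-yl on a thiocarbonyl carbon.

Among the compounds with values here, no measured step touches this ring. All of them alter the chain: a step that the two limits leave unreadable from compound 1 to compound 2, an at least 3.4-fold lower number from compound 1 to compound 3 (0.53 log units; beyond the scatter) and an at least 3.4-fold lower number from compound 2 to compound 3 (0.53 log units; beyond the scatter). Only the two steps to compound 3 can be read, and both are at least modest. Compound 4 keeps the chain of compound 1, so no step beyond the scatter is expected in this assay.

The estimated step is a number no higher from compound 1 to compound 4 (the limit leaves the size open).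

For compound 4 the expected value is 100000 nM, with an estimated range from 40000 nM to 200000 nM.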

Compound 4, half-maximal inhibitory concentration: > 100000 nM
Compound 4: a limit, no number; the forecaster's own chance of this, stated with the estimate: 85%; the middle value sits exactly at the limit.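

Within the data shown here, compound 1 and compound 4 both give only a limit rather than a number, so no step between them can be read: the limit of > 100000 nM in this assay, at which 3 of the 4 values shown sit.

On these data alone, whether pyrrolidin-1-yl in place of piperidin-1-yl changes the activity at all stays open, as does how that swap would behave with the chain of compound 3.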